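Series notes: amine substituent swap on the shared core

This account rests on a few compounds, and the source may have more. Where it says the series, first, only, none or still open, it means among the compounds named here.

Compound 2, `CC(C)Sc1nnc(-c2c(CNc3nc4ccccc4[nH]3)c3ccccc3n2C)n1-c1ccccc1`, stands highest of the two numbers in hand for a physicochemical assay for lipophilicity (on this read-out higher numbers stand for higher lipophilicity and lower numbers for lower lipophilicity), giving 5.94. Going by the values given here, compound 1, `COCCNCc1c(-c2nnc(SC(C)C)n2-c2ccccc2)n(C)c2ccccc12`, gives 4.36 in this assay; the one measured step, a number 1.58 log units higher from compound 1 to compound 2 (beyond the scatter), is large. Compound 3, `COc1ccc(CNCc2c(-c3nnc(SC(C)C)n3-c3ccccc3)n(C)c3ccccc23)cc1`, is not yet measured; its change from compound 2 is 4-methoxybenzyl in place of 1H-benzimidazol-2-yl on an amine nitrogen. Among the compounds with values here, no measured step covers this exact change: the benzimidazolyl group that entered from compound 1 to compound 2 now leaves, and the entering group is a second aromatic ring rather than the short chain of compound 1. Within the data shown here, the only anchor is that compound 1 with a chain gives 4.36, so a benzyl group is expected to sit well above that. Compound 3 is therefore expected to land close to compound 2, with an estimated step of a number 0.14 log units lower from compound 2 to compound 3 (within the scatter). The estimate for compound 3 is 5.8, in the range 5.2 to 6.4.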

Compound 3, partition coefficient: 6.27
Compound 3: middle estimate off by 0.47 log units, on the low side; the range from low to high includes it.
By their numbers in this assay, from the lowest: compound 1; then compound 2; then compound 3.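

In this assay, this place on the amine nitrogen separates two ring-bearing groups of equal heavy-atom count: a number 0.33 log units higher from compound 2 to compound 3 (beyond the scatter), a modest step beyond the scatter, with 4-methoxybenzyl entering and 1H-benzimidazol-2-yl leaving. Against the chain-bearing compound the change is much larger, a number 1.91 log units higher from compound 1 to compound 3 (beyond the scatter), so among these three compounds, most of the spread lies between the 2-methoxyethyl group and either ring-bearing group, and less lies between the two ring-bearing groups. Nothing at hand accounts for the order of the three groups.

The compounds shown leave open how an unsubstituted benzyl group or a longer alkyl chain on the same nitrogen would read, and so how much of the step belongs to the methoxy group. Also open, going by these compounds, is whether the hydrogen-bond donor of 1H-benzimidazol-2-yl bears on the number, a question that a 1-methylbenzimidazol-2-yl group would address.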